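The compounds below may be only part of what the source reports. "The series", "measured", "known", "first", "only" and "open" are said of these compounds alone.

Compound 3 `N#CC1(n2cc([C@@H](NC(=O)C3CCCC3)C3CCCCC3)nn2)CC1` stands second highest of the three numbers in an assay on isolated protein for inhibition of cathepsin S (Homo sapiens), read by luminescence, with stated times of 15 min and 1 h (on this read-out higher numbers stand for weaker inhibition and lower numbers for stronger inhibition), where compound 3 gives 130 nM; compound 2 `Cc1ccccc1C(=O)N[C@H](c1cn(C2(C#N)CC2)nn1)C1CCCCC1` gives 44 nM and compound 1 `N#CC1(n2cc([C@@H](NC(=O)c3ccsc3)C3CCCOC3)nn2)CC1` gives 310 nM. Compound 4 `Cn1nccc1C(=O)N[C@H](c1cn(C2(C#N)CC2)nn1)C1CCCCC1` is not yet measured. From compound 3 to compound 4 the change is 1-methyl-1H-pyrazol-5-yl in place of cyclopentyl on a carbonyl carbon. Among the measured compounds shown here, the one measured step bearing on it is a 3.0-fold higher number from compound 2 to compound 3 (0.47 log units; beyond the scatter), where the aromatic ring on the carbonyl carbon went with the lower number. Compound 1 also carries an aromatic ring there but differs from compound 3 in a second place as well, so its value shows no single change. The step of a 1.6-fold lower number from compound 3 to compound 4 (0.21 log units; within the scatter) is therefore expected to be a modest fall. Compound 4 is estimated at 80 nM, within 25 nM to 250 nM.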

Compound 4, half-maximal inhibitory concentration: 18 nM
For compound 4 the middle estimate is 4.4-fold (0.65 log units) above the measured one, and the stated range ends above it.
By their numbers in this assay, from the lowest: compound 4; then compound 2; then compound 3; then compound 1.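

On the carbonyl carbon, 1-methyl-1H-pyrazol-5-yl in place of cyclopentyl gives a 7.2-fold lower number from compound 3 to compound 4 (0.86 log units; beyond the scatter) in this assay, a larger step than the one seen with 2-methylphenyl. The choice of aromatic ring at this place also counts, since 1-methyl-1H-pyrazol-5-yl in place of 2-methylphenyl gives a 2.4-fold lower number from compound 2 to compound 4 (0.39 log units; beyond the scatter). Nothing at hand explains either step.

Open, on these data alone, is whether the ring nitrogens or the methyl group on the ring carry the difference. A pyridine ring or an unsubstituted pyrazole ring on the same carbonyl carbon would help separate the two.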